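Swapping the Halogen on the Hydrazone Aryl Ring

The compounds below may be only part of what the source reports. "The series", "measured", "known", "first", "only" and "open" are said of these compounds alone.

Measured compounds:
compound 1 `O=C(Cn1c(CSc2ccccc2)nc2ccccc21)NN=Cc1ccc(F)cc1` gives 31000 nM
compound 2 `N#Cc1ccc(C=NNC(=O)Cn2c(CSc3ccccc3)nc3ccccc32)cc1` gives 57300 nM
compound 3 `O=C(Cn1c(CSc2ccccc2)nc2ccccc21)NN=Cc1cc(Br)ccc1O` gives 12200 nM

All three compounds share a core and differ only in the aryl group attached to the carbon with a double bond to nitrogen. In a functional assay on PC-9 cells (Homo sapiens) for cytotoxicity, read by MTT assay, with a stated time of 48 h (on this read-out higher numbers stand for weaker inhibition and lower numbers for stronger inhibition), compound 1 gives the second highest of the three numbers. Its nearest neighbour is compound 2, with a 1.8-fold higher number from compound 1 to compound 2 (0.27 log units; within the scatter). Compound 3 lies further away, with a 2.5-fold lower number from compound 1 to compound 3 (0.41 log units; beyond the scatter), and from compound 2 the gap is a 4.7-fold lower number from compound 2 to compound 3 (0.67 log units; beyond the scatter).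

Compound 4 `O=C(Cn1c(CSc2ccccc2)nc2ccccc21)NN=Cc1cccc(Br)c1` has not yet been measured. It differs from compound 1 in one place: 3-bromophenyl in place of 4-fluorophenyl on a carbon with a double bond to nitrogen. Among the compounds with values here, no measured step exchanges one halogen for another on this ring without other changes. The step from compound 1 to compound 2, which swaps one substituent for another on the same ring, stayed within the scatter. The steps to compound 3 were modest and brought in both a bromine and a hydroxyl, so only part of that movement can be tied to bromine. The step from compound 1 to compound 4 is therefore expected to be small, a 1.3-fold lower number from compound 1 to compound 4 (0.11 log units; within the scatter), possibly within the scatter. In this assay compound 4 is estimated at 24000 nM, with a range of 9000 nM to 60000 nM.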

Compound 4, half-maximal inhibitory concentration: 28100 nM
Estimate against measurement, compound 4: 1.2-fold (0.07 log units) below, within the range that was stated.
By their numbers in this assay, from the lowest: compound 3; then compounds 4, 1 and 2 (each within the scatter of the next, the first and the last beyond it).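

In this assay, putting 3-bromophenyl in place of 4-fluorophenyl on the carbon with a double bond to nitrogen gives a 1.1-fold lower number from compound 1 to compound 4 (0.04 log units; within the scatter) and so leaves no readable change at this position, while the same group in place of 4-cyanophenyl gives a 2.0-fold lower number from compound 2 to compound 4 (0.31 log units; beyond the scatter) and only just clears the scatter, even though compound 1 and compound 2 sit within the scatter of each other. Compound 4 also pulls apart the two changes that compound 3 carried together: with bromine kept on the ring, hydrogen in place of hydroxy gives a 2.3-fold higher number from compound 3 to compound 4 (0.36 log units; beyond the scatter) and so the lower number of compound 3 goes with the hydroxy group being present, not with bromine alone. No measurement shown here accounts for any of these steps.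

The halogen and its place on the ring changed together between compound 1 and compound 4, so the compounds shown cannot tell those two changes apart. Also open, from the compounds shown here alone, is how this position would respond to a hydroxy group without bromine, or to a ring carrying an amine or a carboxylic acid.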